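Bromo in place of hydrogen on compound 2

A few compounds are considered here, and "the series" means these few. Any claim that something is new, unique, unknown or untested is made for them only; others in the source may bear on it.

In a functional assay on OE21 cells (Homo sapiens) for antiproliferative activity, read by MTT assay, with a stated time of 72 h (a higher number here means a weaker inhibitor, a lower number a stronger inhibitor), compound 1 (`O=C1Nc2c(Cl)cccc2/C1=C1/Nc2ccccc2C1=O`) gives 35300 nM and compound 2 (`O=C1Nc2ccccc2/C1=C1/Cc2ccccc2C1=O`) gives 25100 nM as the second value of the series. These two numbers lie within the scatter of each other, so compound 2 stands level with compound 1 on the data so far. Compound 3 (`O=C1Nc2ccc(Br)cc2/C1=C1/Cc2ccccc2C1=O`) carries bromo in place of hydrogen on an aromatic carbon of compound 2 (bromo in place of hydrogen on an aromatic carbon) and has not yet been measured. Among the compounds with values here, no two measured compounds differ in one place only, so no measured step bears on this change, and the expectation rests on the structural change alone. A moderate step toward a lower number is expected in this assay (a 2.1-fold lower number from compound 2 to compound 3 (0.32 log units; beyond the scatter)) although a result within the scatter would not surprise. The expected value for compound 3 is 12000 nM with an estimated range from 4000 nM to 32000 nM in these cells.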

Compound 3, half-maximal inhibitory concentration: 56000 nM
For compound 3 the middle estimate is 4.7-fold (0.67 log units) below the measured one, outside the stated range (above it).
By their numbers in this assay, from the lowest: compounds 2, 1 and 3 (each within the scatter of the next, the first and the last beyond it).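

In this assay, within the data shown here, bromo in place of hydrogen on an aromatic carbon, meta to a fused ring and para to a fused ring, gives a 2.2-fold higher number from compound 2 to compound 3 (0.35 log units; beyond the scatter), the first step that can be read at a single place. This position therefore responds to substitution, and with this group the number moves modestly toward a weaker inhibitor, so bromo here brings no gain in antiproliferative activity over hydrogen. No measurement shown bears on why the number rises.

A single step cannot show whether the rise belongs to bromo itself or to any group on this carbon. The compounds shown also leave open how fluoro, an amine or a carboxylic acid would behave on the same carbon, and how bromo would behave on another carbon of this ring.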